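Ethyl Ester in Place of a Carboxylic Acid

This account rests on a few compounds, and the source may have more. Where it says the series, first, only, none or still open, it means among the compounds named here.

Compound 1 `C/C=C/C(=O)Nc1cccc(Cn2nc(-c3ccc(Oc4ccccc4)cc3)cc2C(=O)O)c1` carries a free carboxylic acid on its core. In a functional assay on JeKo-1 cells (Homo sapiens) for inhibition, read by luminescence and CellTiter-Glo, with a stated time of 72 h (a lower number here means a stronger inhibitor, a higher number a weaker inhibitor), compound 1 gives only a limit of the assay, > 60000 nM. Compound 3 `C/C=C/C(=O)Nc1cccc(Cn2nc(-c3ccc(Oc4ccccc4)cc3)cc2C(=O)OCC)c1` differs from compound 1 by ethyl in place of hydrogen on an oxygen next to a carbonyl group, and in this assay compound 3 gives 16700 nM. The step is an at least 3.5-fold lower number from compound 1 to compound 3 (0.55 log units; beyond the scatter); its true size is known only as a lower bound due to the limit of > 60000 nM in this assay, at which 2 of the 3 values shown sit.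

Compound 2 `C=CC(=O)N1CCCC(n2nc(-c3ccc(Oc4ccccc4)cc3)cc2C(=O)O)C1` is built on a different core; the difference between the two cores is not broken down here. In this assay compound 2 gives a limit as well, > 60000 nM. Within the data shown here, compound 4 `C=CC(=O)N1CCCC(n2nc(-c3ccc(Oc4ccccc4)cc3)cc2C(=O)OCC)C1` differs from compound 2 by ethyl in place of hydrogen on an oxygen next to a carbonyl group, the same change as the one from compound 1 to compound 3.

Because the same change gave an at least 3.5-fold lower number from compound 1 to compound 3 (0.55 log units; beyond the scatter), compound 4 is expected to show a step of an at least 3.0-fold lower number from compound 2 to compound 4 (0.47 log units; beyond the scatter). Compound 4 is therefore estimated at 20000 nM, expected to lie between 5000 nM and 70000 nM, with a real chance that it, too, returns only a limit.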

Compound 4, half-maximal inhibitory concentration: 21200 nM
Compound 4: middle estimate off by 1.1-fold (0.03 log units), on the low side; measured number inside the range.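

On the core of compound 2, the change from carboxy to ethoxycarbonyl moves the result in this assay in the same direction as on the core of compound 1, giving an at least 2.8-fold lower number from compound 2 to compound 4 (0.45 log units; beyond the scatter). In these two pairs, then, the ethyl ester gives the lower number on both cores, and the steps can be set side by side: the same change on two cores in this assay, an at least 3.5-fold lower number (0.55 log units; beyond the scatter) from compound 1 to compound 3 and an at least 2.8-fold lower number (0.45 log units; beyond the scatter) from compound 2 to compound 4; the limit leaves it open whether they differ. This shows a shared direction rather than a shared size, and two cores cannot show how the change would behave on a third, because each step starts from a limit and is known only as a lower bound: the limit of > 60000 nM in this assay, at which 2 of the 4 values shown sit.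

The compounds shown leave open how a methyl group, or a longer chain such as butyl, would read on that same oxygen of either core. They also leave open how either core would read with an amine in place of the carboxylic acid.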